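The compounds below may be only part of what the source reports. "The series", "measured", "known", "first", "only" and "open" are said of these compounds alone.

Going by the values given here, compound 2, with the structure `O=C(NNc1nncc2ccccc12)C1CC1c1ccc(OCC(F)(F)F)cc1`, is one of two compounds tested so far in a functional assay on U-373MG ATCC cells (Homo sapiens) for inhibition, read by MTT assay, with a stated time of 72 h (on this read-out lower numbers stand for stronger inhibition and higher numbers for weaker inhibition), where compound 2 gives 25000 nM. The other, compound 1, has the structure `O=C(NNC(=O)C1CC1c1ccc(OC(F)(F)F)cc1)c1ccncc1` and in this assay compound 1 gives 37000 nM. On these two numbers compound 2 and compound 1 sit together: their gap lies within the usual scatter of such measurements, so neither can be called the more active on this read-out.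

Compound 3, with the structure `CCOc1ccc(C2CC2C(=O)NNc2nncc3ccccc23)cc1`, has not yet been tested in this assay. It differs from compound 2 in one place only: methyl in place of trifluoromethyl on a saturated chain carbon bound to an oxygen on an aromatic ring. Among the compounds with values here, no measured pair shows what such a change does on this read-out, so there is nothing in the data to point either way. Given that compound 2 gives 25000 nM, the expectation for compound 3 is a step of about no change at the digits printed from compound 2 to compound 3 (within the scatter), that is, no change beyond the scatter in either direction. The estimate for compound 3 in this assay is therefore 25000 nM, with a likely range from 8000 nM to 80000 nM.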

Compound 3, half-maximal inhibitory concentration: 91000 nM
Compound 3: middle estimate off by 3.6-fold (0.56 log units), on the low side; the whole stated range lies below it.
By their numbers in this assay, from the lowest: compounds 2 and 1 (each within the scatter of the next); then compound 3.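

Going by these compounds alone, until now no measured pair spoke to this place on the molecule. The change of 2,2,2-trifluoroethoxy to ethoxy, with methyl in place of trifluoromethyl on a saturated chain carbon bound to an oxygen on an aromatic ring, now gives a 3.6-fold higher number from compound 2 to compound 3 (0.56 log units; beyond the scatter) in this assay, a modest step but one beyond the scatter. So the end of this chain is not a silent spot on this read-out: within this pair, the trifluoromethyl form gives the lower number and therefore the stronger inhibition, though nothing available here accounts for the difference.

The compounds shown leave open how the read-out would respond to other groups at this place, such as a longer propyl chain or an amine at the end of the chain. This is also a single pair on one core, so whether the same change gives a step of similar size on another core remains an open question.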